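The source may report more compounds than this note shows. Statements on the series, on what has been measured and on what is new or still open speak of the compounds shown alone.

Within the data shown here, in an ADME assay on J774.A1 cells (Mus musculus) for inhibition, read by MTT assay, with a stated time of 72 h (a higher number here means that more compound is needed for the effect, a lower number that less compound is needed), compound 1 `Cc1ccc(CNc2nc(NCc3ccccc3)nc3ccccc23)cc1` gives 2100 nM and compound 2 `Cc1ccc(CNc2nc(NCc3ccc(C)cc3)c3ccccc3n2)cc1` gives 2900 nM, so compound 1 stands level with the only other measured compound. Compound 3 `CC(C)Nc1nc(NCc2ccccc2)nc2ccccc12` differs from compound 1 by a single change: isopropyl in place of 4-methylbenzyl on a nitrogen on an aromatic ring. Among the measured compounds shown here, the only measured step, a 1.4-fold higher number from compound 1 to compound 2 (0.14 log units; within the scatter), involves just a methyl on an aromatic carbon, so it says little about this much larger exchange. A modest move to a higher number is expected, though with low confidence. For compound 3 the estimated value is 4500 nM, within an expected range of 1800 nM to 12000 nM. That would be an expected 2.1-fold higher number from compound 1 to compound 3 (0.33 log units; beyond the scatter).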

Compound 3, half-maximal effective concentration: 7200 nM
Beside the measured number, compound 3's estimate is 1.6-fold (0.20 log units) below it; low and high end bracket the measured number.
By their numbers in this assay, from the lowest: compounds 1 and 2 (each within the scatter of the next); then compound 3.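

Among these compounds, exchanging 4-methylbenzyl for isopropyl on this nitrogen gives a 3.4-fold higher number from compound 1 to compound 3 (0.54 log units; beyond the scatter) in this assay, the first step that lies beyond the scatter. The number therefore responds to the group on this nitrogen, which the methyl step did not show. Nothing available explains the rise.

Isopropyl differs from 4-methylbenzyl both in having no ring and in having fewer heavy atoms, so the compounds shown leave open which difference counts. A cyclohexyl or a longer chain on this nitrogen would help separate the two.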